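Amide aryl swap on a shared core: expecting compound 4

This account rests on a few compounds, and the source may have more. Where it says the series, first, only, none or still open, it means among the compounds named here.

Measured compounds:
compound 1, `CCn1cc(C(=O)Nc2ccccc2N)c(=O)c2cc(F)c(N3CCNC(C)C3)c(F)c21`: 5900 nM
compound 2, `CCn1cc(C(=O)Nc2ccc(Cl)cn2)c(=O)c2cc(F)c(N3CCNC(C)C3)c(F)c21`: 3300 nM
compound 3, `CCn1cc(C(=O)Nc2ccc(C)c([N+](=O)[O-])c2)c(=O)c2cc(F)c(N3CCNC(C)C3)c(F)c21`: 3700 nM

The three compounds share one core and differ only in the aryl group on the amide-type nitrogen. In a functional assay on A549 cells (Homo sapiens) for cytotoxicity, read by MTT assay (a higher number here means a weaker inhibitor, a lower number a stronger inhibitor), compound 1 gives 5900 nM, compound 2 gives 3300 nM and compound 3 gives 3700 nM. Compound 3 holds the second highest of the three numbers, with compound 2 nearest and compound 1 furthest, and all three sit within the scatter of one another.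

Compound 4, `CCn1cc(C(=O)Nc2cc([N+](=O)[O-])ccc2F)c(=O)c2cc(F)c(N3CCNC(C)C3)c(F)c21`, has not yet been measured in this assay. The change from compound 3 is 2-fluoro-5-nitrophenyl in place of 4-methyl-3-nitrophenyl on an amide-type nitrogen. Among the compounds with values here, the steps that bear on it are a 1.8-fold lower number from compound 1 to compound 2 (0.25 log units; within the scatter), a 1.6-fold lower number from compound 1 to compound 3 (0.20 log units; within the scatter) and a 1.1-fold higher number from compound 2 to compound 3 (0.05 log units; within the scatter): each of these swaps of the aryl group on the amide-type nitrogen left this assay unchanged beyond the scatter. Since compound 4 carries yet another aryl group of the same size in the same place, no step beyond the scatter is expected in either direction.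

Compound 4 is therefore estimated at 4000 nM, with a range from 1500 nM to 12000 nM, which means an expected step of a 1.1-fold higher number from compound 3 to compound 4 (0.03 log units; within the scatter).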

Compound 4, half-maximal inhibitory concentration: 1700 nM
The estimate for compound 4 lay 2.4-fold (0.37 log units) above the measured number; the range from low to high includes it.
By their numbers in this assay, from the lowest: compounds 4, 2, 3 and 1 (each within the scatter of the next, the first and the last beyond it).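

In this assay, within the data shown here, the aryl group on the amide-type nitrogen now gives steps beyond the scatter, which no swap among the earlier compounds did: 2-fluoro-5-nitrophenyl in place of 4-methyl-3-nitrophenyl gives a 2.2-fold lower number from compound 3 to compound 4 (0.34 log units; beyond the scatter) and in place of 2-aminophenyl gives a 3.5-fold lower number from compound 1 to compound 4 (0.54 log units; beyond the scatter), both modest. The same group in place of 5-chloropyridin-2-yl gives a 1.9-fold lower number from compound 2 to compound 4 (0.29 log units; within the scatter), so the position responds to some swaps but this one stays inside the scatter. No measurement at hand accounts for these steps.

The compounds shown do not separate the part played by the fluorine from that of the nitro group, since compound 3 and compound 4 differ in both the substituents and their arrangement on the ring. From the compounds shown here alone, how a carboxylic acid or a longer alkyl chain would read in this place also stays open.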